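Sec-butyl to isobutyl on the amine nitrogen

The source may hold more compounds than are shown below. What is called first, only, known or untested is meant among the compounds shown, and "the series" means these compounds.

In an ADME assay on Caco-2 cells (Homo sapiens) for inhibition, read by MTT assay, with a stated time of 72 h (a higher number here means a weaker inhibitor, a lower number a stronger inhibitor), compound 1 (`CCC(C)NC(=C\C(=O)/C=C/c1ccc(O)c(OC)c1)/C=C/c1ccc(O)c(OC)c1`) gives > 25000 nM as a limit of the assay, not a number. Compound 2 (`COc1cc(/C=C/C(=O)CC(=O)/C=C/c2ccc(OC(C)=O)c(OC)c2)ccc1OC(C)=O`) likewise gives > 25000 nM as a limit. For the measured compounds named here, both therefore sit at one shared limit (the limit of > 25000 nM in this assay, at which 2 of the 2 values shown sit), and no measured step gives a size to work from. Compound 3 (`COc1cc(/C=C/C(=O)/C=C(/C=C/c2ccc(O)c(OC)c2)NCC(C)C)ccc1O`) carries isobutyl in place of sec-butyl on an amine nitrogen. No change beyond the scatter is expected in this assay, and the estimated step that the limit leaves unreadable from compound 1 to compound 3 has no expected direction. Compound 3 is estimated at 30000 nM within an expected range of 12000 nM to 60000 nM in this series.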

Compound 3, half-maximal inhibitory concentration: > 25000 nM
Compound 3 gave a limit, no number; the forecaster's own chance of this, stated with the estimate: 70%; the middle value is on the limit's open side.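

Compound 1 and compound 3 both stand at a limit in this assay, so no step can be read between them: the limit of > 25000 nM in this assay, at which 3 of the 3 values shown sit.

The compounds shown leave open whether isobutyl in place of sec-butyl on an amine nitrogen changes inhibition at all.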